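From compound 2 to compound 3: an amide-nitrogen swap

The compounds below may be only part of what the source reports. "The series", "measured", "known", "first", "only" and "open" are said of these compounds alone.

In an ADME assay on MT4 cells (Homo sapiens) for cytotoxicity, read by MTT assay (on this read-out lower numbers stand for higher toxicity in this test and higher numbers for lower toxicity in this test), compound 1 (`Cc1ccc(NC(=O)CSc2nncnc2-c2cccc3ccccc23)c([N+](=O)[O-])c1`) gives 147000 nM and compound 2 (`O=C(CSc1nncnc1-c1cccc2ccccc12)Nc1ccc([N+](=O)[O-])cc1Cl`) gives 150000 nM on the same read-out. These two numbers lie within the scatter of each other, so compound 2 holds no separate place in this small set.

Compound 3 (`O=C(CSc1nncnc1-c1cccc2ccccc12)Nc1ccccc1F`) keeps the core of compound 2 and carries 2-fluorophenyl in place of 2-chloro-4-nitrophenyl on an amide-type nitrogen.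

For the measured compounds named here, one measured step bears on this place, with 2-chloro-4-nitrophenyl in place of 4-methyl-2-nitrophenyl: it shows a 1.0-fold higher number from compound 1 to compound 2 (0.01 log units; within the scatter) and stands alone as evidence. Going by the values given here, both groups in that step carry a nitro group and the entering 2-fluorophenyl does not, so no measured step covers this exact change.

No step beyond the scatter is therefore expected in this assay and no firm direction is expected either. The expected step is a 1.1-fold lower number from compound 2 to compound 3 (0.03 log units; within the scatter) on this estimate. For compound 3 the estimate is 140000 nM with an expected range from 55000 nM to 300000 nM on this read-out.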

Compound 3, half-maximal cytotoxic concentration: 65000 nM
The estimate for compound 3 lay 2.2-fold (0.33 log units) above the measured number; measured number inside the range.
By their numbers in this assay, from the lowest: compound 3; then compounds 1 and 2 (each within the scatter of the next).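

In this assay the group on the amide-type nitrogen can move the number beyond the scatter, with 2-fluorophenyl in place of 2-chloro-4-nitrophenyl (a 2.3-fold lower number from compound 2 to compound 3 (0.36 log units; beyond the scatter)) and in place of 4-methyl-2-nitrophenyl (a 2.3-fold lower number from compound 1 to compound 3 (0.35 log units; beyond the scatter)), both towards higher toxicity in this test. Compound 1 and compound 2, which both carry a nitro group, stay within the scatter of each other, while compound 3, which has none, stands apart on the lower side, though both steps are modest and three compounds support no general rule. No measurement on these compounds accounts for the change.

The swap removes the nitro group, brings in fluorine and goes from 10 heavy atoms to 7 all at once, so the compounds shown do not tell which of these goes with the lower number, and plain phenyl or 2-chlorophenyl on the same nitrogen would separate them. Also open, as far as these compounds go, is how a group without an aromatic ring, such as cyclohexyl or a short chain ending in an amine, would read at this place.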